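Swapping methoxy for fluoro on compound 2

This account rests on a few compounds, and the source may have more. Where it says the series, first, only, none or still open, it means among the compounds named here.

In an ADME assay on HUVEC cells (Homo sapiens) for cytotoxicity, read by MTT assay, with a stated time of 72 h (on this read-out higher numbers stand for weaker inhibition and lower numbers for stronger inhibition), compound 2 (`COc1ccc(/C=C2\CC[C@H]3C(C)(C)CCC[C@]3(C)[C@H]2CCC(C)CC(=O)O)cc1`) gives > 200000 nM as its reading, which is a limit and not a number. Compound 1 (`C=C1CC[C@H]2C(C)(C)CCC[C@]2(C)[C@H]1CCC(C)CC(=O)OC`) gives > 200000 nM as its reading, again a limit. Compound 3 (`CC(CC[C@H]1/C(=C/c2ccc([N+](=O)[O-])cc2)CC[C@H]2C(C)(C)CCC[C@]12C)CC(=O)O`) gives 194000 nM as a true number. Compound 4 (`CC(CC[C@H]1/C(=C/c2ccc(F)cc2)CC[C@H]2C(C)(C)CCC[C@]12C)CC(=O)O`) carries fluoro in place of methoxy on an aromatic carbon. Within the data shown here, the closest measured change, nitro in place of methoxy, was an at least 1.0-fold lower number from compound 2 to compound 3 (0.01 log units; that floor lies within the scatter) and no larger step has been seen. Also relevant is the limit of > 200000 nM in this assay, at which 2 of the 3 values shown sit, for these compounds. No step beyond the scatter is therefore expected in this assay from this swap. The step expected is a number no higher from compound 2 to compound 4 (the limit leaves the size open) by this estimate. Compound 4 is estimated at 200000 nM with 120000 nM to 330000 nM as its expected range.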

Compound 4, half-maximal inhibitory concentration: > 200000 nM
Compound 4 ended at the assay's limit; the forecaster's own chance of this, stated with the estimate: 60%; the middle value lies on the limit itself.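

Replacing nitro with fluoro on this aromatic carbon gives an at least 1.0-fold higher number from compound 3 to compound 4 (0.01 log units; that floor lies within the scatter). In this assay, the fluoro and methoxy compounds both read as limits, so the step between them cannot be read. The fluoro result adds one more reading to those already at this limit, leaving this position with little measurable range: the limit of > 200000 nM in this assay, at which 3 of the 4 values shown sit.

As far as these compounds go, whether fluoro and methoxy differ at all in this read-out stays open. So does whether an amine or a longer chain on this aromatic carbon would give a reading clearly under the limit.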